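Adding acetyl to the phenyl group of compound 2

The compounds below may be only part of what the source reports. "The series", "measured", "known", "first", "only" and "open" are said of these compounds alone.

In a functional assay (Nicotiana tabacum) (a lower number here means a stronger inhibitor, a higher number a weaker inhibitor), compound 1 `CCCNc1nc(SC)nc2ncccc12`, which carries propyl on a nitrogen on an aromatic ring, gives 270 nM. Compound 2 `CSc1nc(Nc2ccccc2)c2cccnc2n1` has phenyl in that place and gives 15900 nM. That change is a 59-fold higher number from compound 1 to compound 2 (1.77 log units; beyond the scatter). Compound 3 `CSc1nc(Nc2ccc(Cl)cc2)c2cccnc2n1`, with chloro in place of hydrogen on an aromatic carbon, gives 8510 nM. This second change is a 1.9-fold lower number from compound 2 to compound 3 (0.27 log units; within the scatter). Compound 2 and compound 3 thus share the high end of the numbers seen so far, well away from compound 1.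

Compound 4 `CSc1nc(Nc2cccc(C(C)=O)c2)c2cccnc2n1` departs from compound 2 by acetyl in place of hydrogen on an aromatic carbon, meta to a large group. The large first step replaced the whole group on the nitrogen, so it says little about this change. The chloro step is the closer guide, since it also adds a group to an aromatic carbon, and it stayed within the scatter. Going by the values given here, no measured compound carries acetyl, so this guide is indirect. No step beyond the scatter is therefore expected in this assay. The expected change is a 1.6-fold lower number from compound 2 to compound 4 (0.20 log units; within the scatter). Compound 4 is estimated at 10000 nM, with an expected range from 3000 nM to 30000 nM.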

Compound 4, half-maximal inhibitory concentration: 13200 nM
Beside the measured number, compound 4's estimate is 1.3-fold (0.12 log units) below it; low and high end bracket the measured number.
By their numbers in this assay, from the lowest: compound 1; then compounds 3, 4 and 2 (each within the scatter of the next).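

In this assay, acetyl on an aromatic carbon, meta to a large group, produces only a small shift (a 1.2-fold lower number from compound 2 to compound 4 (0.08 log units; within the scatter)), so the phenyl group of compound 2 accepts at this place a group of 3 heavy atoms, with a carbonyl and a hydrogen-bond acceptor, without a change that can be read. Going by these compounds alone, until now the chloro of compound 3 was the only added group on this ring, and one group alone could not show whether such additions generally stay within the scatter; compound 4 gives a second case, with a larger and different group, that does. Nothing measured on these compounds speaks to why this step stays so small.

The compounds shown leave open whether an amine or a carboxylic acid on this same aromatic carbon would also stay within the scatter of compound 2, which stands at 15900 nM. They also leave open whether any group on the phenyl ring can win back the large loss seen on replacing propyl (a 59-fold higher number from compound 1 to compound 2 (1.77 log units; beyond the scatter)), or whether a longer chain on the nitrogen is the better route.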